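The compounds below may be only part of what the source reports. "The series", "measured", "known", "first", "only" and "open" are said of these compounds alone.

Measured compounds:
compound 1, `Cc1ccc(N2CC[C@@H](NC(=O)Nc3ccccc3Br)C2)cc1F`, 8.3
compound 2, `O=C(Nc1ccccc1Br)N[C@@H]1CCN(c2ccccn2)C1`, < 6.6

Compound 1 carries a 3-fluoro-4-methylphenyl on the ring amine nitrogen, and in a functional assay for antagonist activity at transient receptor potential cation channel subfamily V member 1 (Rattus norvegicus), read by FLIPR (on this read-out lower numbers stand for lower potency and higher numbers for higher potency (the scale is a negative logarithm)), compound 1 gives 8.3. For compound 2 this assay returns only a limit, < 6.6, so its true value is not known. For the measured compounds named here, the one measured step, a number at least 1.70 log units lower from compound 1 to compound 2 (beyond the scatter), leaves compound 2 at the limit of < 6.6 in this assay, at which 1 of the 2 values shown sits.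

Compound 3, `O=C(Nc1ccccc1Br)N[C@@H]1CCN(c2cc(C(F)(F)F)ccn2)C1`, differs from compound 2 by trifluoromethyl in place of hydrogen on an aromatic carbon. Going by the values given here, no measured step touches this kind of change: the only step on hand concerns the swap of the whole aryl group, not a substituent on the pyridine. What can be said is that compound 2 starts at a limit, so any effect of the trifluoromethyl cannot be gauged against it. An expectation for compound 3 rests on that limit alone and is wide. Compound 3 is estimated at 6.8, in the range 6 to 7.6, which would mean an expected step of a number at least 0.20 log units higher from compound 2 to compound 3 (that floor lies within the scatter).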

Compound 3, negative logarithm of the antagonist equilibrium constant: 6.9
For compound 3 the middle estimate is 0.10 log units below the measured one; measured number inside the range.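

Trifluoromethyl in place of hydrogen, on an aromatic carbon opposite the ring nitrogen of the pyridin-2-yl group, gives a number at least 0.30 log units higher from compound 2 to compound 3 (that floor lies within the scatter). Compound 2 stands only at a limit, so this step gives a floor and not a size: the limit of < 6.6 in this assay, at which 1 of the 3 values shown sits.

What is new is that a compound with a pyridin-2-yl group on the ring amine nitrogen now has a measured number, since in this assay compound 3 gives 6.9. Whether trifluoromethyl raises the number at this position therefore stays unsettled by these compounds. They also leave open how a nitrile, a methyl or a methoxy group would read at this same position, and how trifluoromethyl would read on another carbon of that ring.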